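Macrocycle series: aromatic ring restored on the side chain

A few compounds are considered here, and "the series" means these few. Any claim that something is new, unique, unknown or untested is made for them only; others in the source may bear on it.

In an assay on isolated protein for displacement of a labelled ligand from Motilin receptor (Homo sapiens) (on this read-out higher numbers stand for weaker inhibition and lower numbers for stronger inhibition), compound 1 `CCC[C@@H]1NC(=O)[C@@H](C(C)C)NC(=O)[C@@H](Cc2ccc(O)cc2)NCCOc2ccccc2CCCNC1=O` gives 55 nM. Among the measured compounds shown here, compound 2 `CCC[C@@H]1NC(=O)[C@@H](C(C)C)NC(=O)[C@@H](CC2CCCCC2)NCCOc2ccccc2CCCNC1=O` gives 3250 nM in this assay, the highest of the two numbers so far, and differs from compound 1 in one place: a 59-fold higher number from compound 1 to compound 2 (1.77 log units; beyond the scatter). Compound 3 `CCC[C@@H]1NC(=O)[C@@H](C(C)C)NC(=O)[C@@H](CCc2ccccc2)NCCOc2ccccc2CCCNC1=O` has not been measured in this assay. Relative to compound 2 the change is benzyl in place of cyclohexyl on a saturated chain carbon bound to a saturated ring carbon; the same difference cut one bond further out reads cyclohexylmethyl to phenethyl. For the measured compounds named here, the only measured step that bears on this is the one from compound 1 to compound 2, which exchanged an aromatic ring for a saturated one and gave a large rise. Compound 3 brings an aromatic ring back, though without the hydroxyl of compound 1. A downward step in this assay is therefore expected, of size a 4.1-fold lower number from compound 2 to compound 3 (0.61 log units; beyond the scatter). Compound 3 is estimated at 800 nM in this assay, with a range from 200 nM to 3500 nM.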

Compound 3, inhibition constant: 1490 nM
Compound 3: the middle estimate sits 1.9-fold (0.27 log units) below what was measured; the range from low to high includes it.
By their numbers in this assay, from the lowest: compound 1; then compound 3; then compound 2.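

In this assay, the change from cyclohexyl to benzyl on a saturated chain carbon bound to a saturated ring carbon gives only a modest gain (a 2.2-fold lower number from compound 2 to compound 3 (0.34 log units; beyond the scatter)), so an aromatic ring at this position does not by itself restore the number of compound 1. The gap to the hydroxylated compound stays large (a 27-fold higher number from compound 1 to compound 3 (1.43 log units; beyond the scatter)), but this step removes the hydroxyl and also adds one carbon, since the change reads cyclohexylmethyl to phenethyl at one bond further out, and the two effects cannot be told apart. No supporting data bear on why these numbers differ.

The compounds shown leave open how much of that gap belongs to the hydroxyl and how much to the longer chain. Also open, from the compounds shown here alone, is whether a 4-methoxyphenyl or 4-aminophenyl group at this position would stand nearer to compound 1 or to compound 3.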